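Notes: double-bond change from compound 1 to compound 4

A few compounds are considered here, and "the series" means these few. Any claim that something is new, unique, unknown or untested is made for them only; others in the source may bear on it.

Measured so far:
- compound 1 `CC(=O)OC/C(=C\c1ccccc1F)C(=O)c1ccccc1` gives 68700 nM
- compound 2 `COc1ccc(C(=O)/C(=C/c2ccccc2F)COC(C)=O)cc1` gives 22500 nM
- compound 3 `COc1ccc(C(=O)/C(=C/c2ccc(Cl)cc2Cl)CC(C)OC(C)=O)cc1` gives 40300 nM

Among the measured compounds shown here, these values come from a functional assay on A549 cells (Homo sapiens) for inhibition, read by XTT assay, with a stated time of 48 h (a higher number here means a weaker inhibitor, a lower number a stronger inhibitor), and cover only three compounds. Compound 1 stands at the upper end of these numbers, although compound 1 and compound 3 lie within the scatter of each other. Compound 2 is separated from it by a modest step, a 3.1-fold lower number from compound 1 to compound 2 (0.48 log units; beyond the scatter), beyond the scatter.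

Compound 4 `CC(=O)OC/C(=C/c1ccccc1F)C(=O)c1ccccc1` is the next case, and the change is the two compounds have the same atoms and bonds and differ only in configuration as drawn: 1 of 1 stereo elements differ; a double bond is drawn E in compound 1 and Z in compound 4. That measured step comes from methoxy in place of hydrogen on an aromatic carbon, so its size says nothing direct about a change of configuration. For the measured compounds named here, no measured pair here differs in configuration alone, and the data give no direction for this change. The expected change is therefore small, with a 1.1-fold lower number from compound 1 to compound 4 (0.06 log units; within the scatter) as the estimated step in this assay and an uncertain sign. Compound 4 is expected at 60000 nM with an estimated range from 25000 nM to 150000 nM in this wide band.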

Compound 4, half-maximal inhibitory concentration: 20300 nM
The estimate for compound 4 lay 3.0-fold (0.47 log units) above the measured number; the whole stated range lies above it.
By their numbers in this assay, from the lowest: compounds 4, 2, 3 and 1 (each within the scatter of the next, the first and the last beyond it).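

In this assay, the configuration of the double bond matters on its own: going from E to Z gives a 3.4-fold lower number from compound 1 to compound 4 (0.53 log units; beyond the scatter). The earlier compounds shown here offered a single-change step only for methoxy in place of hydrogen on an aromatic carbon, a 3.1-fold lower number from compound 1 to compound 2 (0.48 log units; beyond the scatter), so configuration now stands as a second single change that moves the number. The step can be assigned to configuration alone, with no other structural change to share it, because of this: the fact that compounds 1 and 4 differ only in the configuration as drawn.

On these data alone, whether the Z drawing gives a similar step on the cores of compound 2 and compound 3 remains open, since this one pair carries the whole reading. Also open, as far as these compounds go, is how an amine or a carboxylic acid in place of the acetate ester would read in either configuration.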